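From ethylsulfonyl to propanoyl on the amine nitrogen

The source may report more compounds than this note shows. Statements on the series, on what has been measured and on what is new or still open speak of the compounds shown alone.

In an ADME assay on microsomes from liver (Mus musculus) for metabolic stability, read by LC-MS, using NADPH, with stated times of 10 min and 30 min (a higher number here means faster removal of the compound, a lower number slower removal), compound 1 (`CC1CN(c2cccnc2)C(=O)c2ccc(Cl)cc21`) gives 45 mL/min/kg and compound 2 (`CCC1c2cc(Cl)ccc2C(=O)N1c1cccnc1`) gives 65.9 mL/min/kg as its clearance. Compound 3 (`CCS(=O)(=O)N[C@@H]1CCCc2c1cncc2N1Cc2cc(Cl)ccc2C1=O`) gives 27 mL/min/kg as its clearance, within the scatter of compound 1 and beyond the scatter under compound 2.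

Compound 4 (`CCC(=O)N[C@@H]1CCCc2c1cncc2N1Cc2cc(Cl)ccc2C1=O`) is still unmeasured. Compared with compound 3, it has propanoyl in place of ethylsulfonyl on an amine nitrogen. For the measured compounds named here, no measured pair shows this change alone, and compound 1 and compound 2 differ from compound 3 in more than one place. The data therefore give no direct size for the change. The expectation in this assay is a modest rise that stays within the scatter, anchored on compound 3 at 27 mL/min/kg as the closest measured structure. The expected size is a 1.3-fold higher number from compound 3 to compound 4 (0.10 log units; within the scatter) on this estimate, with no step beyond the scatter foreseen. Compound 4 is expected at 34 mL/min/kg in this assay, with an estimated range from 17 mL/min/kg to 62 mL/min/kg as the likely span.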

Compound 4, clearance: < 20.2 mL/min/kg
Compound 4 was reported as a limit; the forecaster's own chance of this, stated with the estimate: 2%; middle value at least 1.6-fold (0.22 log units) away from the limit.
By their numbers in this assay, from the lowest: compounds 3, 1 and 2 (each within the scatter of the next, the first and the last beyond it). At a limit, below all of these: compound 4.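

In this assay, compound 4 gives < 20.2 mL/min/kg, which is a limit and not a number. Propanoyl in place of ethylsulfonyl on the amine nitrogen gives an at least 1.3-fold lower number from compound 3 to compound 4 (0.12 log units; that floor lies within the scatter), the first reading of this change in the series, so clearance at this position does not depend on keeping the ethylsulfonyl group. The size of the step stays unknown, as compound 4 is read only at a limit: the limit of < 20.2 mL/min/kg in this assay, at which 1 of the 4 values shown sits.

Open, going by these compounds, is whether acetyl, a longer acyl chain or a urea on the same amine nitrogen stays in this low range of clearance. Also open, on these data alone, is whether the step carries over to other cores, as compound 1 and compound 2 differ from compound 3 in more than one place.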